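Swapping the Aryl Group on Sulfur

The compounds below may be only part of what the source reports. "The series", "measured", "known", "first", "only" and "open" are said of these compounds alone.

Compound 1 `Nc1ccccc1NC(=O)/C=C/c1ccc(CSc2ccc(Cl)cc2)cc1`: 59.6%
Compound 2 `Nc1ccccc1NC(=O)/C=C/c1ccc(CSc2cccc(F)c2)cc1`: 56.6%

In a functional assay on A549 cells (Homo sapiens) for inhibition, read by CCK-8 assay, with a stated time of 72 h, tested at 8 uM (on this read-out higher numbers stand for more inhibition of growth at the one concentration tested and lower numbers for less inhibition of growth), compound 2 gives 56.6%, which sits within the scatter of compound 1. Compound 3 `CCc1ccc(SCc2ccc(/C=C/C(=O)Nc3ccccc3N)cc2)cc1` has 4-ethylphenyl in place of 3-fluorophenyl on a sulfur. Among the compounds with values here, only one measured step bears on this change, as it also exchanges the group on that sulfur: a number 3 percentage points lower from compound 1 to compound 2 (within the scatter). That single small step gives no basis for expecting a change beyond the scatter. The expected move is a number 1.4 percentage points higher from compound 2 to compound 3 (within the scatter). For compound 3 the estimated value is 58%, with an expected range of 46% to 69%.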

Compound 3, percent growth inhibition at one concentration: 68.6%
Compound 3: the middle estimate sits 10.6 percentage points below what was measured; measured number inside the range.
By their numbers in this assay, from the lowest: compounds 2, 1 and 3 (each within the scatter of the next, the first and the last beyond it).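

In this assay, within the data shown here, changing the group on this sulfur moves the number beyond the scatter for the first time (a number 12 percentage points higher from compound 2 to compound 3 (beyond the scatter)), so this position is not indifferent to the aryl group it carries. Ethyl in place of chloro on an aromatic carbon, however, stays within the scatter (a number 9 percentage points higher from compound 1 to compound 3 (within the scatter)), so that change cannot be told apart from no effect. No measurement shown here explains either step. On these data alone, what an amine or a carboxylic acid on this aromatic ring would do remains open, as does the effect of a longer chain in place of ethyl.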